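Hydroxyethyl on the Amine: Sigma Binding Expectation

A few compounds are considered here, and "the series" means these few. Any claim that something is new, unique, unknown or untested is made for them only; others in the source may bear on it.

Of the compounds shown here, two sharing one core have been tested in an assay on brain for displacement of a labelled ligand from Sigma non-opioid intracellular receptor 1 (Cavia porcellus), with a stated time of 120 min; on this read-out higher numbers stand for weaker inhibition and lower numbers for stronger inhibition. Compound 1, `Cc1nn(-c2ccc(C(N)=O)c(NC3CC4CCCC(C3)C4NCc3ccccc3)c2)c2c1C(=O)CC(C)(C)C2`, carries a benzyl group on its amine nitrogen. In this assay compound 1 gives > 1000 nM, which is a limit of the assay rather than a number. Compound 2, `Cc1nn(-c2ccc(C(N)=O)c(NC3CC4CCCC(C3)C4N)c2)c2c1C(=O)CC(C)(C)C2`, carries a hydrogen in its place. In this assay compound 2 gives > 1000 nM, again a limit of the assay. The step that the two limits leave unreadable from compound 1 to compound 2 therefore cannot be read, since (the limit of > 1000 nM in this assay, at which 2 of the 2 values shown sit). Compound 3, `Cc1nn(-c2ccc(C(N)=O)c(NC3CC4CCCC(C3)C4NCCO)c2)c2c1C(=O)CC(C)(C)C2`, is not yet measured; it differs from compound 2 by 2-hydroxyethyl in place of hydrogen on an amine nitrogen. Among the compounds with values here, the only measured step, from benzyl to hydrogen, is unreadable, so nothing shows how a group on this nitrogen moves binding. Compound 2 sits at the limit. Compound 3 is expected to stay near that limit, a step that the limit leaves unreadable from compound 2 to compound 3. Compound 3 is therefore estimated at 3000 nM, within 800 nM to 20000 nM.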

Compound 3, inhibition constant: > 1000 nM
Compound 3: only a limit was reported; the forecaster's own chance of this, stated with the estimate: 75%; the middle value does not contradict the limit.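

In this assay compound 3 gives > 1000 nM (a limit of the assay, not a number). No step among compound 1, compound 2 and compound 3 can be read: the limit of > 1000 nM in this assay, at which 3 of the 3 values shown sit.

Going by these compounds, how strongly these compounds bind, and whether the group on the amine nitrogen alters that binding, stays open.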